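The source may hold more compounds than are shown below. What is called first, only, known or untested is meant among the compounds shown, and "the series" means these compounds.

Compound 1 `COC(=O)c1cc(/C=C\c2cc(OC)ccc2OC)ccc1OC`: 30200 nM
Compound 2 `COc1ccc(OC)c(C#Cc2ccc(OC)c(C(=O)O)c2)c1`: 38200 nM

In a functional assay on SN12C cells (Homo sapiens) for antiproliferative activity (a higher number here means a weaker inhibitor of growth, a lower number a stronger inhibitor of growth), compound 1 gives 30200 nM and compound 2 gives 38200 nM. Among the compounds with values here, these two values lie within the scatter of each other, so compound 1 cannot be separated from the only other measured compound. Compound 3 `CCCCCCNC(=O)c1cc(/C=C\c2cc(OC)ccc2OC)ccc1OC` keeps the core of compound 1 and carries hexylamino in place of methoxy on a carbonyl carbon. The same difference, cut one bond further out, reads methoxycarbonyl to hexylcarbamoyl. Within the data shown here, no measured pair shows a single change at this place, so the expectation rests on judgment and stays loose. A moderate move toward stronger growth inhibition is expected, beyond the scatter but with real doubt about its size. The estimated change is a 3.4-fold lower number from compound 1 to compound 3 (0.53 log units; beyond the scatter). For compound 3 the estimated value is 9000 nM, with an expected range of 1500 nM to 40000 nM.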

Compound 3, concentration for 50% growth inhibition: 63100 nM
For compound 3 the middle estimate is 7.0-fold (0.85 log units) below the measured one; the whole stated range lies below it.
By their numbers in this assay, from the lowest: compounds 1, 2 and 3 (each within the scatter of the next, the first and the last beyond it).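

Hexylamino in place of methoxy on a carbonyl carbon gives a 2.1-fold higher number from compound 1 to compound 3 (0.32 log units; beyond the scatter) in this assay. Within the data shown here, this is the first single change read at this place, and it shows that going from methoxycarbonyl to hexylcarbamoyl on the core of compound 1 modestly weakens growth inhibition rather than strengthening it. Nothing measured here bears on why the number rises.

The single step joins two differences, the carbonyl substituent's nitrogen and its hexyl chain, and the compounds shown do not separate them. Methylamino on the same carbonyl carbon would test the nitrogen with a much shorter chain, while octylamino would show whether a longer chain continues the direction seen with hexylamino.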